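Methyl-to-Hydrogen Swap on an Aromatic Nitrogen

The compounds below may be only part of what the source reports. "The series", "measured", "known", "first", "only" and "open" are said of these compounds alone.

In a functional assay on KB403 cells (Homo sapiens) for cytotoxicity, read by MTT assay, with stated times of 6 h and 48 h (a lower number here means a stronger inhibitor, a higher number a weaker inhibitor), compound 1 `Cn1c(/C=C/C(=O)c2ccccc2O)cc(Br)c1Br` gives 8320 nM. Compound 2 `O=C(/C=C/c1cc(Br)c(Br)[nH]1)c1ccccc1O` reaches only the limit of the measurement, >= 100000 nM. The step of an at least 12-fold higher number from compound 1 to compound 2 (1.07 log units; beyond the scatter) is therefore a large one, and the pair touches (the limit of >= 100000 nM in this assay, at which 1 of the 3 values shown sits). Compound 3 `Cn1c(-c2cc(-c3ccccc3O)no2)cc(Br)c1Br` gives 2450 nM, the lowest number of the two that are known; how its core differs from the core of compound 1 is not broken down here. Compound 4 `Oc1ccccc1-c1cc(-c2cc(Br)c(Br)[nH]2)on1` has not yet been measured. It differs from compound 3 by hydrogen in place of methyl on an aromatic nitrogen, the same kind of change as hydrogen in place of methyl on an aromatic nitrogen, made at a place described in identical words. Because the measured pair gave an at least 12-fold higher number from compound 1 to compound 2 (1.07 log units; beyond the scatter), compound 4 is expected to stand far above compound 3, a step of a 16-fold higher number from compound 3 to compound 4 (1.21 log units; beyond the scatter), with a real chance that only a limit is reported. The estimate for compound 4 in this assay is 40000 nM, between 12000 nM and 100000 nM.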

Compound 4, half-maximal inhibitory concentration: 16400 nM
Compound 4: the middle estimate sits 2.4-fold (0.39 log units) above what was measured, and the stated range covers the measured number.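

In this assay, hydrogen in place of methyl on an aromatic nitrogen again moves the number up on the second core, a 6.7-fold higher number from compound 3 to compound 4 (0.83 log units; beyond the scatter), so the direction of the change holds on both cores shown. Compound 2 gives only a limit of the assay, >= 100000 nM, and not a number. The two steps therefore show a shared direction but fix no shared size for the change: the same change on two cores in this assay, an at least 12-fold higher number (1.07 log units; beyond the scatter) from compound 1 to compound 2 and a 6.7-fold higher number (0.83 log units; beyond the scatter) from compound 3 to compound 4; the limit leaves it open whether they differ

The compounds shown leave open whether another group on this nitrogen, such as an ethyl group, a longer chain or a chain ending in an amine or a carboxylic acid, would keep the lower numbers seen with methyl. They also leave open how the change behaves on any core beyond these two.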